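Compound 3 to compound 4: one added group

The source may report more compounds than this note shows. Statements on the series, on what has been measured and on what is new or still open speak of the compounds shown alone.

Values measured in a functional assay on HeLa cells (Homo sapiens) for cytotoxicity, read by MTT assay, with a stated time of 72 h (on this read-out higher numbers stand for weaker inhibition and lower numbers for stronger inhibition), are:
- Compound 1 `CC(C)(C)C1=CC(=O)C=C(NCC(=O)O)C1=O` gives 132000 nM
- Compound 2 `CC1=CCC[C@H]2[C@](C)(CC3=CC(=O)C(N4CCC[C@H]4C(=O)O)=CC3=O)[C@@H](C)CC[C@]12C` gives 36200 nM
- Compound 3 `CC1=CCC[C@H]2[C@](C)(CC3=CC(=O)C=CC3=O)[C@@H](C)CC[C@]12C` gives 18100 nM

Compound 3 and compound 2 share the low end of these numbers, within the scatter of each other, while compound 1 lies clearly higher than compound 3.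

Compound 4 `CC1=CCC[C@H]2[C@](C)(CC3=CC(=O)C=C(N[C@@H](C(=O)O)C(C)C)C3=O)[C@@H](C)CC[C@]12C` differs from compound 3 by one change: (1-carboxy-2-methylpropyl)amino in place of hydrogen on a double-bonded ring carbon with (1-carboxy-2-methylpropyl)amino in place of hydrogen on a double-bonded ring carbon. Among the compounds with values here, the only related measured step is a 2.0-fold lower number from compound 2 to compound 3 (0.30 log units; within the scatter) and it involves a different group. A step beyond the scatter is therefore not expected in this assay for this change. The expected step is a 1.7-fold higher number from compound 3 to compound 4 (0.22 log units; within the scatter) as a rough estimate. For compound 4 the estimated value is 30000 nM within an expected range of 12000 nM to 80000 nM overall.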

Compound 4, half-maximal inhibitory concentration: 10900 nM
Compound 4: the middle estimate sits 2.8-fold (0.44 log units) above what was measured; measured number below the stated range.
By their numbers in this assay, from the lowest: compounds 4, 3 and 2 (each within the scatter of the next, the first and the last beyond it); then compound 1.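

In this assay, this double-bonded ring carbon takes (1-carboxy-2-methylpropyl)amino, a group of 8 heavy atoms with no ring, in place of hydrogen, giving a 1.7-fold lower number from compound 3 to compound 4 (0.22 log units; within the scatter). The earlier step on a double-bonded ring carbon, a 2.0-fold lower number from compound 2 to compound 3 (0.30 log units; within the scatter), involved the ring-bearing 2-carboxypyrrolidin-1-yl, so a group without a ring now also gives a step within the scatter. Nothing measured here explains this result. From the compounds shown here alone, whether a methyl ester in place of the carboxylic acid, or a plain amine on this carbon, would also stay within the scatter of compound 3 remains open.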